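The compounds below may be only part of what the source reports. "The series", "measured", "known", "first", "only" and "open" are said of these compounds alone.

Three thiosemicarbazones have been tested in a functional assay on HL-60 cells (Homo sapiens) for antiproliferative activity, read by sulforhodamine B assay, with a stated time of 72 h; a lower number here means a stronger inhibitor, a higher number a weaker inhibitor. Compound 1 `CN(C)C(=S)N/N=C/c1cc2cccnc2s1` reaches only the edge of the measurement: in this assay compound 1 gives > 100000 nM, a limit rather than a number (the limit of > 100000 nM in this assay, at which 1 of the 3 values shown sits). Compound 2 `S=C(N/N=C/c1ccc2ccccc2n1)Nc1cccc(Br)c1` carries a 3-bromophenyl group on the thiourea nitrogen, and in this assay compound 2 gives 53800 nM. Compound 3 `CC(C)c1cccc(C(C)C)c1NC(=S)N/N=C/c1ccc2ccccc2n1` has a differently substituted aryl group in the same position; in this assay compound 3 gives 19500 nM. Of the two numbers that were obtained, compound 2 has the higher one, and its gap to compound 3 lies beyond the usual scatter of repeated measurements.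

Compound 4 `S=C(N/N=C/c1ccc2ccccc2n1)Nc1cccc(Cl)c1` differs from compound 2 in a single place: chloro in place of bromo on an aromatic carbon. No measured pair among these three compounds shows what exchanging one halogen for another does, so the expectation rests only on the small size of the change. The step expected from this exchange, a 1.1-fold lower number from compound 2 to compound 4 (0.03 log units; within the scatter), is one that stays within the scatter, in no particular direction. For compound 4 the estimated value is therefore 50000 nM, with a range from 20000 nM to 130000 nM.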

Compound 4, half-maximal inhibitory concentration: 28800 nM
Compound 4: the middle estimate sits 1.7-fold (0.24 log units) above what was measured; low and high end bracket the measured number.
By their numbers in this assay, from the lowest: compounds 3, 4 and 2 (each within the scatter of the next, the first and the last beyond it). At a limit, above all of these: compound 1.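

Within the data shown here, compound 2 and compound 4 form the first pair here that differs in one place, so the effect of a single change on the aryl group can now be read directly in this assay. Replacing 3-bromophenyl with 3-chlorophenyl gives a 1.9-fold lower number from compound 2 to compound 4 (0.27 log units; within the scatter), so the two halogens cannot be told apart at this position, on an aromatic carbon of the six-membered ring, meta to a large group. This holds for one pair only and says nothing yet about any other exchange, and no measurement shown bears on what lies behind this result.

The compounds shown leave open what happens when this halogen is replaced by something quite different, such as an amine, a methoxy group or a carboxylic acid, or when the position carries only hydrogen, and so whether this position responds to any change at all. They also leave open whether the same exchange of bromo for chloro would give a similar result on a different core, such as that of compound 1.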